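Hydrazone to hydroxyethyl imine on the quinolinone series

A few compounds are considered here, and "the series" means these few. Any claim that something is new, unique, unknown or untested is made for them only; others in the source may bear on it.

Compound 1 `Cc1ccc2[nH]c(=O)c(/C=N/Nc3ccccc3)cc2c1` gives 309000 nM in a functional assay, read by spectrophotometry, with a stated time of 5 min (on this read-out lower numbers stand for stronger inhibition and higher numbers for weaker inhibition), which is the highest of the two numbers in hand. Within the data shown here, compound 2 `O=c1[nH]c2ccccc2cc1/C=N/Nc1ccccc1` gives 306000 nM, and the single step of a 1.0-fold lower number from compound 1 to compound 2 (0.00 log units; within the scatter) sits within the scatter, so the two compounds cannot be ordered. Compound 3 `Cc1ccc2[nH]c(=O)c(/C=N/Nc3ccc([N+](=O)[O-])cc3)cc2c1` is reported as "not active" (no number reported), with no number attached, so its position relative to compound 1 and compound 2 is not known.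

Compound 4 `Cc1ccc2[nH]c(=O)c(/C=N/CCO)cc2c1` differs from compound 1 by 2-hydroxyethyl in place of anilino on a double-bonded nitrogen. Among the measured compounds shown here, no measured step touches this position: the only step in hand, from compound 1 to compound 2, concerns a methyl on an aromatic carbon and is within the scatter, and the pair of compound 1 and compound 3 changes the ring that leaves here, without a number to compare. The data therefore give no direction for the exchange of anilino for 2-hydroxyethyl, and nothing in the series argues for a change beyond the scatter.

For compound 4 the expected value is 350000 nM, with a range from 100000 nM to 1500000 nM. The estimated step of a 1.1-fold higher number from compound 1 to compound 4 (0.05 log units; within the scatter) is taken as flat, with the reservation that, as with compound 3, a result without a number is possible.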

Compound 4, half-maximal inhibitory concentration: 1480000 nM
For compound 4 the middle estimate is 4.2-fold (0.63 log units) below the measured one, and the stated range covers the measured number.
By their numbers in this assay, from the lowest: compounds 2 and 1 (each within the scatter of the next); then compound 4.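

In this assay, among these compounds, the substituent on the double-bonded nitrogen is the first place where a single change goes beyond the scatter: with 2-hydroxyethyl in place of anilino there is a 4.8-fold higher number from compound 1 to compound 4 (0.68 log units; beyond the scatter), which on this read-out means weaker inhibition, though the step is modest. The group that leaves and the group that enters are counted with the same hydrogen-bond donors and acceptors, while the six-membered aromatic ring of carbon only is gone, so this one exchange shows that the position responds but cannot separate the loss of the ring from the arrival of the hydroxyl-bearing chain. No measurement in hand accounts for the size or the direction of this step.

Open, on these data alone, is whether a ring-bearing group such as benzyl, or a chain without the hydroxyl such as ethyl, would sit with compound 1 or with compound 4. A 2-aminoethyl group, a 2-carboxyethyl group or a longer chain such as 3-hydroxypropyl would also test the position, and the nitro-bearing compound 3 cannot be read against either end, as it has no number.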